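This account rests on a few compounds, and the source may have more. Where it says the series, first, only, none or still open, it means among the compounds named here.

In a functional assay on Jurkat cells (Homo sapiens) for antiproliferative activity, read by MTT assay, with a stated time of 72 h (a higher number here means a weaker inhibitor, a lower number a stronger inhibitor), compound 3 `COc1ccc(OC)c(-c2c(C(=O)c3cc(OC)c(OC)c(OC)c3)sc3ccccc23)c1` gives > 10000 nM, which is a limit of the assay and not a number. Compound 4 `CCOc1ccc(-c2c(C(=O)c3cc(OC)c(OC)c(OC)c3)sc3ccccc23)cc1` differs from it as follows: 4-ethoxyphenyl in place of 2,5-dimethoxyphenyl on an aromatic carbon. From the compounds shown here alone, the 4-ethoxyphenyl group is untested, so the nearest evidence comes from compound 1 `COc1cc(C(=O)c2sc3ccccc3c2-c2ccc(C)cc2)cc(OC)c1OC`, with 4-methylphenyl, at 3300 nM, and compound 2 `COc1ccc(-c2c(C(=O)c3cc(OC)c(OC)c(OC)c3)sc3ccccc23)c(OC)c1`, with 2,4-dimethoxyphenyl, at 4000 nM. These two sit within the scatter, as a 1.2-fold higher number from compound 1 to compound 2 (0.08 log units; within the scatter) shows. The steps that bear most directly are an at least 3.0-fold higher number from compound 1 to compound 3 (0.48 log units; beyond the scatter) and an at least 2.5-fold higher number from compound 2 to compound 3 (0.39 log units; beyond the scatter), both modest at minimum and both ending at the 2,5-dimethoxyphenyl group. Leaving that group is therefore expected to reverse them, and the expected change is an at least 2.8-fold lower number from compound 3 to compound 4 (0.45 log units; beyond the scatter), towards a lower number. For compound 4 the estimate is 3500 nM, with an expected range of 1200 nM to 10000 nM.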

Compound 4, half-maximal inhibitory concentration: 4100 nM
Compound 4: middle estimate off by 1.2-fold (0.07 log units), on the low side; the measured number falls inside the stated range.
By their numbers in this assay, from the lowest: compounds 1, 2 and 4 (each within the scatter of the next). At a limit, above all of these: compound 3.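

In this assay the 4-ethoxyphenyl group at this position does not separate from the earlier groups: the steps are a 1.0-fold higher number from compound 2 to compound 4 (0.01 log units; within the scatter) and a 1.2-fold higher number from compound 1 to compound 4 (0.09 log units; within the scatter). Leaving 2,5-dimethoxyphenyl gives an at least 2.4-fold lower number from compound 3 to compound 4 (0.38 log units; beyond the scatter) and leaves compound 3 alone apart from the other three. Compound 3 remains a limit of the assay and not a number: the limit of > 10000 nM in this assay, at which 1 of the 4 values shown sits.

Open, from the compounds shown here alone, is how far compound 3 lies from the others. Also open, going by these compounds, is whether an amine, a carboxylic acid or a chain longer than ethoxy on this phenyl group would stay level with compound 4.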